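The compounds below may be only part of what the source reports. "The series", "measured", "known", "first", "only" and "open" are said of these compounds alone.

Measured in a functional assay on B16-F10 cells (Mus musculus) for inhibition, tested at 5 uM; on this read-out higher numbers stand for more inhibition at the one concentration tested (going by the name of the read-out) and lower numbers for less inhibition:
- compound 1 `CC(/C=C/C1=CCCCC1(C)C)=C\C=C\C(C)=C\COC(=O)c1cc(O)ccc1O`: 25.8%
- compound 2 `COc1cccc(C(=O)OC/C=C(C)/C=C/C=C(C)/C=C/C2=CCCCC2(C)C)c1O`: 16.2%

Compound 2 sits at one end of these two numbers, separated from compound 1 by a number 9.6 percentage points lower from compound 1 to compound 2 (within the scatter). Compound 3 `CC(/C=C/C1=CCCCC1(C)C)=C\C=C\C(C)=C\COC(=O)c1cccc(O)c1O` differs from compound 2 by hydrogen in place of methyl on an oxygen on an aromatic ring. Among the compounds with values here, the only measured step, a number 9.6 percentage points lower from compound 1 to compound 2 (within the scatter), swapped one substituted phenyl for another and stayed within the scatter; no step tests methoxy against hydroxy directly. For compound 3 a step of about a number 3.8 percentage points higher from compound 2 to compound 3 (within the scatter) in this assay is expected, not beyond the scatter. Compound 3 is therefore estimated at 20%, between 8% and 33%.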

Compound 3, a percentage reported as inhibition, at one concentration (the size of the read-out at that concentration, not a potency): 18.6%
The estimate for compound 3 lay 1.4 percentage points above the measured number; the measured number falls inside the stated range.
By their numbers in this assay, from the lowest: compounds 2, 3 and 1 (each within the scatter of the next).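

The first direct test of methoxy to hydroxy on this aromatic ring gives a number 2.4 percentage points higher from compound 2 to compound 3 (within the scatter) in this assay, so this change leaves the result within the usual scatter. Placing 2,3-dihydroxyphenyl where compound 1 carries 2,5-dihydroxyphenyl gives a number 7.2 percentage points lower from compound 1 to compound 3 (within the scatter), so these two ring patterns cannot be told apart here either. Nothing available explains these small steps.

From the compounds shown here alone, it remains open whether an amine or a carboxylic acid on the ring would move the number beyond the scatter. With only one concentration tested, the potency of these compounds also remains open.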